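The source may hold more compounds than are shown below. What is called first, only, known or untested is meant among the compounds shown, and "the series" means these compounds.

In a functional assay on the whole organism with Mus musculus as the target (on this read-out higher numbers stand for an effect only at larger amounts of compound and lower numbers for an effect already at smaller amounts), compound 1 `CN(C)C(=O)Cn1c(-c2ccccc2)nc2cccnc21` gives 35 mg/kg. Compound 2 `CN(C)C(=O)Cn1c(-c2ccco2)nc2cccnc21` gives only a limit, > 100 mg/kg, and not a number. Its true position is therefore open on the upper side. Compound 3 `CN(C)C(=O)Cn1c(-c2ccc(Br)o2)nc2cccnc21` differs from compound 2 by bromo in place of hydrogen on an aromatic carbon, which turns furan-2-yl into 5-bromofuran-2-yl: bromo in place of hydrogen on an aromatic carbon. Going by the values given here, no measured step adds bromo to anything. Among the compounds with values here, the only guide is the change at the same group, an at least 2.8-fold higher number from compound 1 to compound 2 (0.45 log units; beyond the scatter), which shows that altering this group can move the number by at least a modest amount. A step of similar modest size is therefore expected in this assay, toward a lower number, although compound 3 may also stay at the limit. The estimated move is an at least 1.2-fold lower number from compound 2 to compound 3 (0.09 log units; that floor lies within the scatter). For compound 3 the expected value is 80 mg/kg, with an estimated range from 30 mg/kg to 200 mg/kg.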

Compound 3, dose for half-maximal effect: 100 mg/kg
For compound 3 the middle estimate is 1.3-fold (0.10 log units) below the measured one; measured number inside the range.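

In this assay the 5-bromofuran-2-yl group gives a number where furan-2-yl gave none, and 5-bromofuran-2-yl in place of phenyl gives a modest step, a 2.9-fold higher number from compound 1 to compound 3 (0.46 log units; beyond the scatter). Compound 2 has only the limit > 100 mg/kg and no number. The step that adds bromo therefore reads only as a number no higher from compound 2 to compound 3 (the limit leaves the size open), and whether bromo in place of hydrogen changes the dose at all stays unsettled because that step starts from a limit: the limit of > 100 mg/kg in this assay, at which 1 of the 3 values shown sits.

The compounds shown leave open whether another atom or small group at the same place, such as chloro or methyl, would behave like bromo. They also leave open whether a phenyl bearing bromo would keep the lower number seen with the unsubstituted phenyl group.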